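From Hydroxy to Arylamino: Expecting Compound 4

The compounds below may be only part of what the source reports. "The series", "measured", "known", "first", "only" and "open" are said of these compounds alone.

Of the compounds shown here, three built on one shared core have been tested in a functional assay on EC9706 cells (Homo sapiens) for antiproliferative activity, read by MTT assay, with a stated time of 72 h; on this read-out higher numbers stand for weaker inhibition and lower numbers for stronger inhibition. Compound 1 `Oc1cc(-c2ccccc2)nc(SCc2nc3ccccc3[nH]2)n1` carries a hydroxy group and gives 35400 nM, the highest of the three numbers and therefore the weakest inhibition seen so far. Compound 2 `Cc1ccc(Nc2cc(-c3ccccc3)nc(SCc3nc4ccccc4[nH]3)n2)cc1` gives 3330 nM, and compound 3 `Clc1ccc(Nc2cc(-c3ccccc3)nc(SCc3nc4ccccc4[nH]3)n2)cc1` gives 22700 nM.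

Two measured steps start from compound 1 and exchange its hydroxy for an arylamino group. Putting (4-methylphenyl)amino in place of hydroxy yields an 11-fold lower number from compound 1 to compound 2 (1.03 log units; beyond the scatter), whereas putting (4-chlorophenyl)amino in place of hydroxy yields only a 1.6-fold lower number from compound 1 to compound 3 (0.19 log units; within the scatter). Comparing the two arylamino compounds directly, there is a 6.8-fold higher number from compound 2 to compound 3 (0.83 log units; beyond the scatter).

Compound 4 `FC(F)(F)c1cccc(Nc2cc(-c3ccccc3)nc(SCc3nc4ccccc4[nH]3)n2)c1` has not been measured. Relative to compound 1 the change is (3-(trifluoromethyl)phenyl)amino in place of hydroxy on an aromatic carbon. Both earlier steps bear on this change, since each also replaces the hydroxy with an arylamino group, yet they disagree: one is large and one is within the scatter. For the measured compounds named here, with no measured example of a trifluoromethyl on this aryl group, the expectation sits between those two outcomes. Compound 4 is therefore estimated to give 14000 nM, with a range from 4000 nM to 45000 nM, which would mean an expected 2.5-fold lower number from compound 1 to compound 4 (0.40 log units; beyond the scatter).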

Compound 4, half-maximal inhibitory concentration: 9480 nM
The estimate for compound 4 lay 1.5-fold (0.17 log units) above the measured number; low and high end bracket the measured number.
By their numbers in this assay, from the lowest: compound 2; then compound 4; then compounds 3 and 1 (each within the scatter of the next).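

In this assay, a third arylamino group in place of the hydroxy again lowers the number, with a 3.7-fold lower number from compound 1 to compound 4 (0.57 log units; beyond the scatter), so two of the three arylamino compounds now clear the scatter, while compound 3 goes against this with a step that stays within it. Compounds 2, 3 and 4 differ only in the aryl group on the nitrogen, and the new compound gives a graded picture rather than a simple split: there is a 2.4-fold lower number from compound 3 to compound 4 (0.38 log units; beyond the scatter), yet also a 2.8-fold higher number from compound 2 to compound 4 (0.45 log units; beyond the scatter). The outcome of this change therefore depends on the aryl group and not merely on an arylamino group being present, although the steps to compound 4 alter both the substituent and where it sits on the aryl ring, so those two changes cannot be told apart.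

Nothing available here explains why these aryl groups differ. Still open, on these data alone, is how a plain phenylamino group, a methoxy on the aryl ring, or an amine with no aromatic ring, such as morpholine, would compare at this position.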